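From ethylamino to propylamino on compound 1

The source may hold more compounds than are shown below. What is called first, only, known or untested is meant among the compounds shown, and "the series" means these compounds.

Values in a functional assay on MCF7 cells (Homo sapiens) for cytotoxicity, read by MTT assay, with a stated time of 24 h (on this read-out lower numbers stand for stronger inhibition and higher numbers for weaker inhibition), for the measured compounds
Compound 1 `CCNc1cc(-c2ccc(NC(=O)Nc3cccc(Cl)c3)cc2C(F)(F)F)ccn1` gives 1240 nM
Compound 2 `CCNc1cc(-c2ccc(NC(=O)Nc3ccc(OC)cc3)cc2C(F)(F)F)ccn1` gives 5740 nM
Compound 3 `CCNc1cc(-c2ccc(NC(=O)Nc3c(C)cccc3C)cc2C(F)(F)F)ccn1` gives 6950 nM

Compound 1 has the lowest number of the three. Compound 4 `CCCNc1cc(-c2ccc(NC(=O)Nc3cccc(Cl)c3)cc2C(F)(F)F)ccn1` differs from compound 1 by methyl in place of hydrogen on a saturated chain carbon, two bonds along the chain from a nitrogen on an aromatic ring and so carries propylamino in place of ethylamino. Within the data shown here, no measured step touches this chain. The steps available replace 3-chlorophenyl on an amide-type nitrogen, giving a 4.6-fold higher number from compound 1 to compound 2 (0.67 log units; beyond the scatter) with 4-methoxyphenyl and a 5.6-fold higher number from compound 1 to compound 3 (0.75 log units; beyond the scatter) with 2,6-dimethylphenyl in that place. They offer only indirect guidance, so no step beyond the scatter is expected in this assay and neither direction is favoured. The estimate amounts to a 1.0-fold higher number from compound 1 to compound 4 (0.02 log units; within the scatter) as the expected step. Compound 4 is estimated to give 1300 nM and is expected to fall from 600 nM to 2800 nM on repeated measurement.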

Compound 4, half-maximal inhibitory concentration: 8230 nM
For compound 4 the middle estimate is 6.3-fold (0.80 log units) below the measured one, and the stated range ends below it.
By their numbers in this assay, from the lowest: compound 1; then compounds 2, 3 and 4 (each within the scatter of the next).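

In this assay, among these compounds, methyl in place of hydrogen on a saturated chain carbon, two bonds along the chain from a nitrogen on an aromatic ring, gives a 6.6-fold higher number from compound 1 to compound 4 (0.82 log units; beyond the scatter), the first measured step at this chain. A single added carbon is thus enough to move the number beyond the scatter, so this chain does not tolerate every extension. Nothing available explains this step.

As far as these compounds go, whether methylamino, isopropylamino or a butyl chain would follow the same direction remains open. So does whether propylamino would bring a similar step with 4-methoxyphenyl or 2,6-dimethylphenyl on the amide-type nitrogen.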